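Working notes on the amide series: estimating compound 3

The source may report more compounds than this note shows. Statements on the series, on what has been measured and on what is new or still open speak of the compounds shown alone.

In a functional assay on the whole organism (strain Wistar) for inhibition, with Rattus norvegicus as the target, read by paw edema, with stated times of 60 min and 3 h, at a dose of 100 mg/kg by the oral route (on this read-out higher numbers stand for more inhibition at the one dose given (going by the name of the read-out) and lower numbers for less inhibition), compound 1 `CCCCCNC(=O)CC1CCc2cc(OC)c(OC)cc21` gives 37.7%. Compound 2 `CCCCCCNC(=O)CC1CCc2cc(OC)c(OC)cc21` gives 44.6% in this assay, and compound 2 stands with compound 1 as one of two numbers close together, since the step of a number 6.9 percentage points higher from compound 1 to compound 2 (within the scatter) lies within the scatter. Compound 3 `COc1cc2c(cc1OC)C(CC(=O)N1CCNCC1)CC2` carries piperazin-1-yl in place of hexylamino on a carbonyl carbon. Among the measured compounds shown here, no measured step exchanges the amide substituent; the single recorded step, a number 6.9 percentage points higher from compound 1 to compound 2 (within the scatter), is a chain lengthening and bears only loosely on this change, giving no direction beyond the scatter. Compound 3 is therefore estimated at 38%, with a wide range from 18% to 58%. The expected step is a number 6.6 percentage points lower from compound 2 to compound 3 (within the scatter).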

Compound 3, a percentage reported as inhibition, in the whole organism at one dose (the size of the read-out at that dose, not a potency): 42%
Compound 3: middle estimate off by 4 percentage points, on the low side; low and high end bracket the measured number.
By their numbers in this assay, from the lowest: compounds 1, 3 and 2 (each within the scatter of the next).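

In this assay the exchange on the carbonyl carbon gives a number 2.6 percentage points lower from compound 2 to compound 3 (within the scatter) and a number 4.3 percentage points higher from compound 1 to compound 3 (within the scatter) as its two readings. Among the compounds shown here, at this place, then, piperazin-1-yl, a six-membered ring with 2 hetero atoms, stands level with both open chains, pentylamino and hexylamino, and no step here lies beyond the scatter. Nothing available bears on the reason for this result.

Still open, on these data alone, is whether morpholin-4-yl, a benzylamino group or a chain longer than hexylamino on this carbonyl carbon would move the number beyond the scatter.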